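Swapping the 4-nitrobenzyl group of compound 3 for methyl

The compounds below may be only part of what the source reports. "The series", "measured", "known", "first", "only" and "open" are said of these compounds alone.

In a functional assay on Bel7402/5-FU cells (Homo sapiens) for antiproliferative activity, read by MTT assay, with a stated time of 72 h (on this read-out lower numbers stand for stronger inhibition and higher numbers for weaker inhibition), compound 1 `C=C1C(=O)O[C@H]2[C@H]1CC/C(Cn1cc(Cn3cc(F)c(=O)n(Cc4ccccc4)c3=O)nn1)=C\CC[C@@]1(C)O[C@@H]21` gives 8840 nM and compound 2 `C=C1C(=O)O[C@H]2[C@H]1CC/C(Cn1cc(Cn3cc(F)c(=O)n(Cc4ccc(F)cc4)c3=O)nn1)=C\CC[C@@]1(C)O[C@@H]21` gives 4860 nM while compound 3 `C=C1C(=O)O[C@H]2[C@H]1CC/C(COC(=O)Cn1cc(F)c(=O)n(Cc3ccc([N+](=O)[O-])cc3)c1=O)=C\CC[C@@]1(C)O[C@@H]21` gives 4340 nM as its reading. Compound 3 therefore sits within the scatter of compound 2 and beyond the scatter below compound 1. The next molecule, compound 4 `C=C1C(=O)O[C@H]2[C@H]1CC/C(COC(=O)Cn1cc(F)c(=O)n(C)c1=O)=C\CC[C@@]1(C)O[C@@H]21`, differs from compound 3 by hydrogen in place of 4-nitrophenyl on a saturated chain carbon bound to an aromatic nitrogen and this amounts to hydrogen in place of 4-nitrophenyl on a saturated chain carbon bound to an aromatic nitrogen, so 4-nitrobenzyl becomes methyl. Going by the values given here, only one measured step touches this part of the molecule. It is a 1.8-fold lower number from compound 1 to compound 2 (0.26 log units; within the scatter) and it stays within the scatter, but it only adds fluoro to the aromatic ring and does not remove that ring. Among the compounds with values here, no measured compound shows what losing the ring does, so the direction in this assay is uncertain. A slight drift to a higher number is a cautious guess, probably not beyond the scatter. The estimated change is a 1.5-fold higher number from compound 3 to compound 4 (0.18 log units; within the scatter) as a rough expectation. For compound 4 the expected value is 6500 nM with an estimated range from 2800 nM to 15000 nM as the likely span.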

Compound 4, half-maximal inhibitory concentration: 11700 nM
Compound 4: middle estimate off by 1.8-fold (0.26 log units), on the low side, within the range that was stated.
By their numbers in this assay, from the lowest: compounds 3, 2, 1 and 4 (each within the scatter of the next, the first and the last beyond it).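

Replacing 4-nitrobenzyl with methyl gives a 2.7-fold higher number from compound 3 to compound 4 (0.43 log units; beyond the scatter) in this assay and, unlike the earlier fluoro step, this change removes the aromatic ring altogether and lies beyond the scatter. This position is therefore not indifferent to what it carries: with the shared core and linker held constant, the 4-nitrobenzyl group gives the lower number, although the step is only modest. No evidence here accounts for this difference.

The pair cannot separate the contribution of the ring from that of its nitro group, and a plain benzyl group in the same place would be the direct test. From the compounds shown here alone, it also remains open whether an ethyl group or a longer chain would read closer to compound 3 or to compound 4.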